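A few compounds are considered here, and "the series" means these few. Any claim that something is new, unique, unknown or untested is made for them only; others in the source may bear on it.

Working notes on the series in a functional assay on A549 cells (Homo sapiens) for antiproliferative activity, read by MTT assay, with a stated time of 72 h; a lower number here means a stronger inhibitor, a higher number a weaker inhibitor: compound 1 (`Nc1nc(N)c2cc(CSC(=S)N3CCN(c4ccc(Cl)c(Cl)c4)CC3)ccc2n1`) gives 2940 nM, compound 2 (`Nc1nc(N)c2cc(CSC(=S)N3CCN(c4ccc([N+](=O)[O-])cc4)CC3)ccc2n1`) gives 1910 nM, and compound 3 (`Nc1nc(N)c2cc(CSC(=S)N3CCN(c4ccccn4)CC3)ccc2n1`) gives 3960 nM. The place of the last is set by a 1.3-fold higher number from compound 1 to compound 3 (0.13 log units; within the scatter) and a 2.1-fold higher number from compound 2 to compound 3 (0.32 log units; beyond the scatter), so it is level with one and modestly weaker than the other. The remaining exchange on the same ring amine nitrogen gave a 1.5-fold lower number from compound 1 to compound 2 (0.19 log units; within the scatter). Compound 4 (`Nc1nc(N)c2cc(CSC(=S)N3CCN(c4ncccn4)CC3)ccc2n1`) carries pyrimidin-2-yl in place of pyridin-2-yl on an amine nitrogen in a ring. Within the data shown here, these three small steps are the only guide, and none swaps these two groups, so no change beyond the scatter is expected in this assay. The estimated step is a 1.1-fold lower number from compound 3 to compound 4 (0.05 log units; within the scatter). Compound 4 is expected at 3500 nM, with an estimated range of 1600 nM to 7500 nM.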

Compound 4, half-maximal inhibitory concentration: 4010 nM
Estimate against measurement, compound 4: 1.1-fold (0.06 log units) below, within the range that was stated.
By their numbers in this assay, from the lowest: compounds 2, 1, 3 and 4 (each within the scatter of the next, the first and the last beyond it).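

Pyrimidin-2-yl in place of pyridin-2-yl on the ring amine nitrogen gives a 1.0-fold higher number from compound 3 to compound 4 (0.01 log units; within the scatter) and so leaves the two groups level in this assay. Compound 4 stands like compound 3 against the aryl groups, with a 1.4-fold higher number from compound 1 to compound 4 (0.13 log units; within the scatter) and thus level, and with a 2.1-fold higher number from compound 2 to compound 4 (0.32 log units; beyond the scatter) and thus modestly weaker. No measurement at hand accounts for this result.

Going by these compounds, whether a group without an aromatic ring, such as an alkyl chain or a saturated ring bearing an amine, would hold or shift the number on this nitrogen remains open.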